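A few compounds are considered here, and "the series" means these few. Any claim that something is new, unique, unknown or untested is made for them only; others in the source may bear on it.

Measured so far:
- compound 1, `CC(/C=N/Nc1ccc([N+](=O)[O-])cc1)=N\NC(=O)c1ccccc1` — in a functional assay on cells (Splenocyte, Mus musculus, strain BALB/c) for inhibition, read by scintillation counting and thymidine incorporation, with a stated time of 72 h (on this read-out lower numbers stand for stronger inhibition and higher numbers for weaker inhibition), compound 1 gives > 12000 nM
- compound 2, `CC(/C=N/Nc1ccc([N+](=O)[O-])cc1)=N\NC(=O)c1ccc(O)cc1` — compound 2 gives 1510 nM

The value of compound 1 is a limit of the assay, not a number, as told by the limit of > 12000 nM in this assay, at which 1 of the 2 values shown sits. Compound 2 therefore stands as the only true number among the two results shown.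

Among the compounds with values here, the one measured step joins these two compounds: an at least 7.9-fold lower number from compound 1 to compound 2 (0.90 log units; beyond the scatter). Within the data shown here, that is the only evidence available on this pair.

Compound 3, `CC(/C=N/Nc1ccc([N+](=O)[O-])cc1)=N\NC(=O)c1ccc(C(F)(F)F)cc1`, is not yet measured. Compared with compound 2 the change is trifluoromethyl in place of hydroxy on an aromatic carbon. Among the measured compounds shown here, the hydroxy that enters from compound 1 to compound 2 is the same hydroxy that now leaves, so the step from compound 1 to compound 2 bears directly on it, read in the opposite sense, while the entering trifluoromethyl has no measured counterpart here.

Because of an at least 7.9-fold lower number from compound 1 to compound 2 (0.90 log units; beyond the scatter) a return toward the limit of compound 1 is the expected outcome, giving an estimated step of a 5.3-fold higher number from compound 2 to compound 3 (0.72 log units; beyond the scatter). For compound 3 the expected value is 8000 nM, within 2000 nM to 30000 nM, with a real chance that only a limit is reported.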

Compound 3, half-maximal inhibitory concentration: > 12000 nM
Compound 3 ended at the assay's limit (the forecaster's own chance of this, stated with the estimate: 45%); at least 1.5-fold (0.17 log units) between middle value and limit.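

In this assay, trifluoromethyl in place of hydroxy on this aromatic carbon, para to a large group, gives an at least 7.9-fold higher number from compound 2 to compound 3 (0.90 log units; beyond the scatter). Compound 1 had already shown that hydroxy does better than hydrogen here, and this result adds that not just any group on this carbon does the same: among the three compounds, only compound 2, with hydroxy, gives a true number. Compound 3 gives > 12000 nM, which is a limit of the assay and not a number, and the step between compound 1 and compound 3 cannot be read, since both compounds sit at the same limit: the limit of > 12000 nM in this assay, at which 2 of the 3 values shown sit.

Trifluoromethyl differs from hydroxy at once in its heavy atoms and in its hydrogen-bond donors and acceptors, so this pair cannot tell which of these differences matters. As far as these compounds go, whether an amine, a methoxy group or a carboxylic acid on this same carbon would behave like hydroxy or like trifluoromethyl also stays open.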